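Benzimidazole-linked amines: all three measured members sit at limit

A few compounds are considered here, and "the series" means these few. Any claim that something is new, unique, unknown or untested is made for them only; others in the source may bear on it.

Compound 1 `c1ccc(CNCc2nc3c(OCC4CCCCC4)cccc3[nH]2)cc1` carries a benzyl group on the amine nitrogen. In an assay on cells for inhibition of interleukin-5 receptor subunit alpha (Mus musculus), read by WST assay, with a stated time of 48 h, in the presence of a further agent that is not named here (a higher number here means a weaker inhibitor, a lower number a stronger inhibitor), compound 1 returns only the assay limit, > 30000 nM. Compound 2 `COc1ccc(CNCc2nc3c(OCC4CCCCC4)cccc3[nH]2)cc1` differs from compound 1 by methoxy in place of hydrogen on an aromatic carbon. In this assay compound 2 likewise returns only the limit, > 30000 nM. The step that the two limits leave unreadable from compound 1 to compound 2 therefore cannot be read in size. Compound 3 `c1ccc(NCc2nc3c(OCC4CCCCC4)cccc3[nH]2)cc1` differs from compound 1 in its core by phenyl in place of benzyl on an amine nitrogen. In this assay compound 3 again gives only the limit, > 30000 nM. The steps a step that the two limits leave unreadable from compound 1 to compound 3 and a step that the two limits leave unreadable from compound 2 to compound 3 are equally unreadable, which is due to the limit of > 30000 nM in this assay, at which 3 of the 3 values shown sit.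

Compound 4 `COc1ccc(NCc2nc3c(OCC4CCCCC4)cccc3[nH]2)cc1` has not yet been measured; it differs from compound 3 by methoxy in place of hydrogen on an aromatic carbon, the same change as made from compound 1 to compound 2, and at the same place. The expected step that the limit leaves unreadable from compound 3 to compound 4 is set near zero because a step that the two limits leave unreadable from compound 1 to compound 2 showed no readable movement. The estimate for compound 4 in this assay is 40000 nM, with a range from 15000 nM to 120000 nM, most likely reported again as a limit.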

Compound 4, half-maximal inhibitory concentration: > 30000 nM
Compound 4 was reported as a limit; the forecaster's own chance of this, stated with the estimate: 85%; the middle value is on the limit's open side.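

In this assay compound 4 gives > 30000 nM, which is a limit. The steps from compound 1, compound 2 and compound 3 to compound 4 therefore cannot be read in size, due to a single shared ceiling: the limit of > 30000 nM in this assay, at which 4 of the 4 values shown sit.

The compounds shown leave open whether methoxy or the amine substituent changes inhibition at all, since none gives a readable value.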